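Anilino in place of benzoyl(methyl)amino on the shared core

The source may hold more compounds than are shown below. What is called first, only, known or untested is meant among the compounds shown, and "the series" means these compounds.

Measured so far in a physicochemical assay for lipophilicity, using the shake flask method, in phosphate buffer, measured as octanol-water partition, with a stated time of 30 min, at pH 7.4 (on this read-out lower numbers stand for lower lipophilicity and higher numbers for higher lipophilicity), are two compounds
Compound 1 `CN(c1ncco1)c1cnc(NCc2c(F)ccc3c2CCO3)n2cnnc12` gives 2.1
Compound 2 `CN(C(=O)c1ccccc1)c1cnc(NCc2c(F)ccc3c2CCO3)n2cnnc12` gives 2.4

Among the compounds with values here, compound 2 at 2.4 stands within the scatter of compound 1, the only other compound measured, and the two cannot be ordered. Compound 3 `Fc1ccc2c(c1CNc1ncc(Nc3ccccc3)c3nncn13)CCO2` differs from compound 2 by a single change, anilino in place of benzoyl(methyl)amino on an aromatic carbon. Within the data shown here, the one measured step, a number 0.30 log units higher from compound 1 to compound 2 (within the scatter) (benzoyl in place of 1,3-oxazol-2-yl on a nitrogen on an aromatic ring), bears on this only loosely. Among the measured compounds shown here, it stayed within the scatter, and no measured compound carries anilino. In this assay no step beyond the scatter is therefore expected. The expected step is a number 0.10 log units higher from compound 2 to compound 3 (within the scatter) and it remains an estimate. Compound 3 is estimated at 2.5 with an expected range from 2 to 3 on this read-out.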

Compound 3, distribution coefficient: 3.3
Beside the measured number, compound 3's estimate is 0.80 log units below it; measured number above the stated range.
By their numbers in this assay, from the lowest: compounds 1 and 2 (each within the scatter of the next); then compound 3.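

In this assay the group on this aromatic carbon proves able to move the number beyond the scatter: anilino in place of benzoyl(methyl)amino gives a number 0.90 log units higher from compound 2 to compound 3 (beyond the scatter) and anilino in place of methyl(1,3-oxazol-2-yl)amino gives a number 1.20 log units higher from compound 1 to compound 3 (beyond the scatter) on the shared core. Compound 1 and compound 2, both with a methyl-bearing nitrogen at this place and no hydrogen-bond donor in the group, could not be ordered, whereas compound 3, with anilino and its hydrogen-bond donor, stands clear of both. Nothing available gives a reason for this separation.

The compounds shown leave open whether the amide carbonyl, the methyl or the hydrogen on the nitrogen accounts for the step, a question that methyl(phenyl)amino at this place would address. As far as these compounds go, how a pyridin-2-ylamino or benzylamino group would read here also stays open.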